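A Methyl Added to the Shared Core of Compound 2

The source may report more compounds than this note shows. Statements on the series, on what has been measured and on what is new or still open speak of the compounds shown alone.

Compound 2 `FC(F)(F)c1ccc(Nc2ncnc3sc(Nc4c(Cl)cccc4Cl)nc23)cc1Cl` stands at the higher end of the two numbers available: in a functional assay on HEK293 cells for antagonist activity at transient receptor potential cation channel subfamily V member 1 (Rattus norvegicus), read by calcium flux (on this read-out lower numbers stand for stronger inhibition and higher numbers for weaker inhibition), compound 2 gives 9 nM, while its nearest neighbour, compound 1 `FC(F)(F)c1ccc(Nc2ncnc3sc(Nc4c(Cl)cccc4Cl)nc23)cc1`, gives 3 nM in this assay. Within the data shown here, the single measured step, a 3.0-fold higher number from compound 1 to compound 2 (0.48 log units; beyond the scatter), is a chloro in place of hydrogen on an aromatic carbon and is therefore a change of a different kind from the one considered next.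

Compound 3 `Cc1nc(Nc2ccc(C(F)(F)F)c(Cl)c2)c2nc(Nc3c(Cl)cccc3Cl)sc2n1` differs from compound 2 by methyl in place of hydrogen on an aromatic carbon. Among the measured compounds shown here, no measured step in this set involves a methyl group, and the only step that exists concerns a different group on a different ring, so it bears on the present change only by showing that a small added group on the shared scaffold moved the number by a modest amount. He therefore expects the step of a 1.3-fold higher number from compound 2 to compound 3 (0.12 log units; within the scatter) to stay within the scatter or at most to be modest, with no direction firmly indicated. For compound 3 he estimates 12 nM in this assay, with a range from 4 nM to 40 nM.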

Compound 3, half-maximal inhibitory concentration: 2 nM
The estimate for compound 3 lay 6.0-fold (0.78 log units) above the measured number; the measured number lies below the stated range.
By their numbers in this assay, from the lowest: compounds 3 and 1 (each within the scatter of the next); then compound 2.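

In this assay, putting methyl in place of hydrogen on the aromatic carbon between two ring nitrogen atoms gives a lower number (a 4.5-fold lower number from compound 2 to compound 3 (0.65 log units; beyond the scatter)), so this carbon of the six-membered aromatic ring with 2 nitrogen accepts the added methyl and the inhibition grows stronger. Among these compounds, this is the first measured change at this position, and it also runs in the opposite direction from the only earlier step (a 3.0-fold higher number from compound 1 to compound 2 (0.48 log units; beyond the scatter)), where chloro replaced hydrogen on a different ring and the number rose; the two steps together show that a small added group on this scaffold can move the number either way, depending on the group and the place. Nothing in the data given explains why the methyl lowers the number.

As far as these compounds go, whether the gain belongs to methyl alone or would also appear with a longer chain such as ethyl, with an amine or with methoxy on the same carbon remains open. From the compounds shown here alone, it is also open whether methyl would produce a step of similar size on the core of compound 1, which lacks the added chloro.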